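Trimming the Ether on the Shared Core

This account rests on a few compounds, and the source may have more. Where it says the series, first, only, none or still open, it means among the compounds named here.

Of the compounds shown here, three built on one shared core have been measured in an ADME assay on HepG2 cells (Homo sapiens) for cytotoxicity, read by MTT assay, with a stated time of 7 days; a lower number here means a stronger inhibitor, a higher number a weaker inhibitor. Compound 1 `CC(C)Oc1ccc(C2CC(c3ccc(O)cc3)=NN2C(=O)c2cccnc2)cc1` gives 45400 nM. Compound 2 `COc1ccc(C2CC(c3ccc(O)cc3)=NN2C(=O)c2cccnc2)cc1OC` gives 53600 nM, and compound 3 `CCCc1ccc(C2CC(c3ccc(O)cc3)=NN2C(=O)c2cccnc2)cc1` gives 41600 nM. Among these three numbers compound 1 stands second highest, though every gap lies within the scatter: a 1.2-fold higher number from compound 1 to compound 2 (0.07 log units; within the scatter) and a 1.1-fold lower number from compound 1 to compound 3 (0.04 log units; within the scatter), while between the other pair a 1.3-fold lower number from compound 2 to compound 3 (0.11 log units; within the scatter). The unmeasured compound 4 `COc1ccc(C2CC(c3ccc(O)cc3)=NN2C(=O)c2cccnc2)cc1` differs from compound 1 in a single place: methyl in place of isopropyl on an oxygen on an aromatic ring. Within the data shown here, no measured step repeats this exact change; the only bearing comes from the two steps that alter the group on the saturated ring carbon, one exchanging the whole ring substituent and one putting propyl in place of isopropoxy, and neither moved the number beyond the scatter. On that basis the number for compound 4 is expected to shift little: a 1.0-fold higher number from compound 1 to compound 4 (0.01 log units; within the scatter). Compound 4 is therefore estimated at 46000 nM, with a range from 23000 nM to 92000 nM.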

Compound 4, half-maximal inhibitory concentration: 42400 nM
Compound 4: the middle estimate sits 1.1-fold (0.04 log units) above what was measured, and the stated range covers the measured number.
By their numbers in this assay, from the lowest: compounds 3, 4, 1 and 2 (each within the scatter of the next).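

Taking the group on this oxygen from isopropyl down to methyl, the first direct test of that change, leaves the reading in this assay within the scatter (a 1.1-fold lower number from compound 1 to compound 4 (0.03 log units; within the scatter)). The neighbouring exchanges read the same way, with methoxy in place of propyl on the aromatic carbon (a 1.0-fold higher number from compound 3 to compound 4 (0.01 log units; within the scatter)) and hydrogen in place of the extra methoxy of compound 2 (a 1.3-fold lower number from compound 2 to compound 4 (0.10 log units; within the scatter)). Across these compounds, then, the size of the ether, its replacement by a plain propyl chain and a second methoxy all leave the number unresolved from the others, so no order can be drawn among them.

From the compounds shown here alone, whether that flatness would survive an amine, a carboxylic acid or a much longer chain at this place remains open. Nothing here accounts for why these changes leave the number so unmoved.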